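Swapping the ether linker for a benzyl in a coumarin amide

The source may hold more compounds than are shown below. What is called first, only, known or untested is meant among the compounds shown, and "the series" means these compounds.

Measured so far:
- compound 1 `COc1ccc(Oc2ccc3cc(NC(=O)c4ccc(OC(C)=O)c(CC=C(C)C)c4)c(=O)oc3c2C)cc1`: 19500 nM
- compound 2 `COc1ccc(Oc2ccc3cc(NC(=O)c4ccc(OC)c(-c5cccc(OC)c5)c4)c(=O)oc3c2C)cc1`: > 100000 nM
- compound 3 `COc1ccc(Cc2ccc3cc(NC(=O)c4ccc(O)c(CC=C(C)C)c4)c(=O)oc3c2C)cc1OC`: > 100000 nM

Of the compounds shown here, three share a core and have been tested in a functional assay on SK-BR-3 cells (Homo sapiens) for antiproliferative activity; on this read-out lower numbers stand for stronger inhibition and higher numbers for weaker inhibition. Among the compounds with values here, compound 1 is the only one that gives a number, with 19500 nM. For compound 2 the assay reports only a limit, > 100000 nM, not a number. For compound 3 likewise only a limit is reported, > 100000 nM. Within the data shown here, both of these sit at the limit of > 100000 nM in this assay, at which 2 of the 3 values shown sit, so compound 1 stands alone as the one compound with a measurable effect.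

Compound 4 `COCOc1ccc(Cc2ccc3cc(NC(=O)c4ccc(OC(C)=O)c(CC=C(C)C)c4)c(=O)oc3c2C)cc1` has not been measured. It differs from compound 1 in one place: 4-(methoxymethoxy)benzyl in place of 4-methoxyphenoxy on an aromatic carbon. The acetate and the prenyl group on the amide side remain as in compound 1. Compound 3, which also carries a benzyl linker, reached only the limit, while compound 1 with its ether linker gave a number.

On that basis compound 4 is expected to lose potency in this assay, with a step from compound 1 of a 2.3-fold higher number from compound 1 to compound 4 (0.36 log units; beyond the scatter), a change beyond the usual scatter. The estimate for compound 4 is 45000 nM, within a range from 12000 nM to 100000 nM.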

Compound 4, half-maximal inhibitory concentration: 13500 nM
Estimate against measurement, compound 4: 3.3-fold (0.52 log units) above, and the stated range covers the measured number.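

In this assay, putting 4-(methoxymethoxy)benzyl in place of 4-methoxyphenoxy on this aromatic carbon gives a 1.4-fold lower number from compound 1 to compound 4 (0.16 log units; within the scatter), so the two groups cannot be told apart on this read-out. Within the data shown here, the earlier compounds could not show this: the only benzyl-linked compound among them, compound 3, gave no number, whereas compound 4 shows that a benzyl-linked group at this position can go together with a measurable value. Compound 3 also differs from compound 4 in more than one place, so its result cannot be pinned on the linker alone, and it remains one of two compounds that give only a limit rather than a number: the limit of > 100000 nM in this assay, at which 2 of the 4 values shown sit.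

The change to compound 4 replaces the linking atom and the group at the far end of the ring together, so the compounds shown cannot separate the two; a plain 4-methoxybenzyl group would be the direct test of the linker alone. On these data alone, it also remains open whether this position would keep a measurable value with an amine or a carboxylic acid at the far end of the benzyl group, or with a longer chain in its place.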